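Extending the thiosemicarbazide nitrogen substituent from methyl to allyl

The compounds below may be only part of what the source reports. "The series", "measured", "known", "first", "only" and "open" are said of these compounds alone.

Of the compounds shown here, three built on a shared core have been tested in a toxicity assay on the whole organism (P388 cells, strain CDF1) for cytotoxicity, with Mus musculus as the target, with stated times of 6 days and 24 h, at a dose of 5 mg/kg; on this read-out lower numbers stand for a stronger effect and higher numbers for a weaker effect at the one dose given. Compound 1 `NC(=S)N/N=C1/CCCc2cccnc21` gives 6.7% in this assay. Compound 2 `CNC(=S)N/N=C1/CCCc2cccnc21` gives -7.7%, and compound 3 `CNC(=S)N/N=C1\CCCc2cccnc21` gives -12%. The change of methyl in place of hydrogen on an amide-type nitrogen brings a number 14.4 percentage points lower from compound 1 to compound 2 (beyond the scatter). The pair of compound 2 and compound 3 shows a number 4.3 percentage points lower from compound 2 to compound 3 (within the scatter), which fits with the fact that compounds 2 and 3 differ only in the configuration as drawn. Among the three numbers, compound 2 stands second highest, close to compound 3 and further from compound 1.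

The next compound, compound 4 `C=CCNC(=S)N/N=C1/CCCc2cccnc21`, differs from compound 2 by vinyl in place of hydrogen on a saturated chain carbon bound to an amide-type nitrogen. Going by the values given here, only the step from compound 1 to compound 2 touches the substituent on that amide-type nitrogen, and that step was modest; the present change sits one bond further out, on the saturated chain carbon rather than on the nitrogen itself. The account therefore expects a step of a number 4.3 percentage points lower from compound 2 to compound 4 (within the scatter) in this assay, small and most likely within the scatter. For compound 4 the estimate in this assay is -12%, with a range from -30% to 8%.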

Compound 4, a percentage reported as activity, at one dose (the size of the read-out at that dose, not a potency): 0%
Beside the measured number, compound 4's estimate is 12 percentage points below it, within the range that was stated.
By their numbers in this assay, from the lowest: compounds 3, 2, 4 and 1 (each within the scatter of the next, the first and the last beyond it).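

In this assay the step of a number 7.7 percentage points higher from compound 2 to compound 4 (within the scatter) shows that, at this saturated chain carbon bound to an amide-type nitrogen, the change from methyl to allyl cannot be told apart from the scatter. The comparison with hydrogen on the amide-type nitrogen gives a number 6.7 percentage points lower from compound 1 to compound 4 (within the scatter) and so also lies within the scatter, whereas methyl at that nitrogen gave a number 14.4 percentage points lower from compound 1 to compound 2 (beyond the scatter) and lay beyond it; compound 4 thus falls within the scatter of both compound 1 and compound 2, and the clear step seen with methyl does not reappear with allyl. What is known about these compounds offers no explanation for this result.

The compounds shown leave open whether a saturated propyl group, a longer chain such as butyl, or a benzyl group on this nitrogen would read apart from compound 2 or compound 1 in this assay and so show a real trend with the substituent. They also leave open whether the allyl compound, drawn with the opposite double bond configuration, would stay as close to compound 4 as compound 3 does to compound 2.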